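Methyl on the phenyl ring of two related cores

The compounds below may be only part of what the source reports. "The series", "measured", "known", "first", "only" and "open" are said of these compounds alone.

Compound 1 `O=c1[nH]cc(S(=O)(=O)Nc2cccc(-c3cn(-c4ccccc4)nn3)c2)c(=O)[nH]1` and compound 3 `O=c1[nH]cc(S(=O)(=O)Nc2ccc(-c3cn(-c4ccccc4)nn3)cc2)c(=O)[nH]1` have the same atoms joined differently; the difference between the two cores is not broken down here. In a functional assay on SGC-7901 cells (Homo sapiens) for antiproliferative activity, read by MTT assay, with a stated time of 24 h (on this read-out lower numbers stand for stronger inhibition and higher numbers for weaker inhibition), compound 1 gives 17200 nM and compound 3 gives 18800 nM, numbers that lie within the scatter of each other. Compound 2 `Cc1ccc(-n2cc(-c3cccc(NS(=O)(=O)c4c[nH]c(=O)[nH]c4=O)c3)nn2)cc1` differs from compound 1 by methyl in place of hydrogen on an aromatic carbon, the methyl standing para to a large group; in this assay compound 2 gives 9430 nM, and the step of a 1.8-fold lower number from compound 1 to compound 2 (0.26 log units; within the scatter) stays within the scatter. Compound 4 `Cc1ccccc1-n1cc(-c2ccc(NS(=O)(=O)c3c[nH]c(=O)[nH]c3=O)cc2)nn1` is not yet measured. It differs from compound 3 by methyl in place of hydrogen on an aromatic carbon, the same kind of change, but with the methyl ortho to a large group rather than para to it, so the earlier pair is a guide only by kind. Because the step of a 1.8-fold lower number from compound 1 to compound 2 (0.26 log units; within the scatter) was within the scatter, only a small effect is expected from adding the methyl here. For compound 4 the expected step is a 1.6-fold lower number from compound 3 to compound 4 (0.19 log units; within the scatter). Compound 4 is therefore estimated at 12000 nM in this assay, with an expected range from 6000 nM to 30000 nM.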

Compound 4, half-maximal inhibitory concentration: 13600 nM
For compound 4 the middle estimate is 1.1-fold (0.05 log units) below the measured one; the range from low to high includes it.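

In this assay, for the compounds shown here, the change from phenyl to 2-methylphenyl gives a 1.4-fold lower number from compound 3 to compound 4 (0.14 log units; within the scatter), so on this core too the methyl produces no step that can be told from the scatter. Set beside the step on the other core, the change carries across the two cores with no difference that can be read: the same change on two cores in this assay, a 1.8-fold lower number (0.26 log units; within the scatter) from compound 1 to compound 2 and a 1.4-fold lower number (0.14 log units; within the scatter) from compound 3 to compound 4, 1.3-fold (0.12 log units) apart, within the scatter of two such steps This shows only that the two small steps agree; with both inside the scatter, it does not show that the methyl has a real effect on either core, and since the methyl does not stand in the same place in the two pairs, the role of the core cannot be separated from that of the place.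

The compounds shown leave open whether a step large enough to read would carry between the cores in the same way, for instance with an amine, a carboxylic acid or a longer chain in place of the methyl. They also leave open whether the agreement holds on any other cell line.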